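The source may report more compounds than this note shows. Statements on the series, on what has been measured and on what is new or still open speak of the compounds shown alone.

Compound 1 `Cc1cnc(Nc2ccc([N+](=O)[O-])cc2)nc1Nc1nc2ccccc2s1` gives > 50000 nM in a functional assay on PC-3 cells (Homo sapiens) for antiproliferative activity, read by MTT assay, with a stated time of 48 h; on this read-out lower numbers stand for stronger inhibition and higher numbers for weaker inhibition.
Compound 2 `Cc1ccc2nc(Nc3nc(Nc4ccc(S(N)(=O)=O)cc4)ncc3C)sc2c1` gives 2710 nM in this assay.
Compound 3 `CS(=O)(=O)c1ccc(Nc2nccc(Nc3nc4ccccc4s3)n2)cc1` gives 1710 nM in this assay.

The account follows the step from compound 1 to compound 4 `Cc1cnc(Nc2ccc(F)cc2)nc1Nc1nc2ccccc2s1`, which has not yet been measured. Compound 1 stands apart from the other two: its result is a limit of the assay and not a number, and it is the only one of the three to sit at the limit of > 50000 nM in this assay, at which 1 of the 3 values shown sits. Compound 2 and compound 3 both give numbers, and the two lie within the usual scatter of each other. Compound 4 differs from compound 1 in one place (fluoro in place of nitro on an aromatic carbon). For the measured compounds named here, no step between two measured compounds has been recorded, so the change has nothing to be calibrated against, and the outcome for compound 4 is open. A gain beyond the scatter is nonetheless expected for compound 4 in this assay, though it may also remain at the limit. The estimate for compound 4 is 20000 nM, expected to fall between 3000 nM and 60000 nM. The step this expectation implies is an at least 2.5-fold lower number from compound 1 to compound 4 (0.39 log units; beyond the scatter).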

Compound 4, half-maximal inhibitory concentration: > 50000 nM
Compound 4: only a limit was reported; the forecaster's own chance of this, stated with the estimate: 35%; middle value at least 2.5-fold (0.39 log units) away from the limit.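

In this assay compound 1 and compound 4 both give only a limit of the assay and not a number, so no step between them can be read: the limit of > 50000 nM in this assay, at which 2 of the 4 values shown sit.

The compounds shown leave open whether fluoro in place of nitro changes the result for this core at all in this assay.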